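Removing a methoxy group: what to expect for compound 4

The source may hold more compounds than are shown below. What is called first, only, known or untested is meant among the compounds shown, and "the series" means these compounds.

Compound 1 `CC1(c2ccccc2)CC(=O)N(CC(=O)N2CCN(c3ccc(Cl)cc3)CC2)C1=O`: "not active" (no number reported)
Compound 2 `Cc1cccc(N2CCN(C(=O)CN3C(=O)CC(C)(c4ccccc4)C3=O)CC2)c1`: 300 mg/kg
Compound 3 `COc1cccc(N2CCN(C(=O)CN3C(=O)CC(C)(c4ccccc4)C3=O)CC2)c1`: "not active" (no number reported)

Three compounds share one core and differ only in the group on the outer aromatic ring. In a functional assay on the whole organism (strain CD-1) with Mus musculus as the target, in the maximal electroshock model, with a stated time of 2 h (on this read-out lower numbers stand for an effect already at smaller amounts and higher numbers for an effect only at larger amounts of compound), compound 2 gives 300 mg/kg, whereas compound 1 gives "not active" (no number reported) and compound 3 gives "not active" (no number reported). Compound 3 therefore stands with compound 1 among the entries without a number; compound 2 alone has one. The step to compound 4 `CC1(c2ccccc2)CC(=O)N(CC(=O)N2CCN(c3ccccc3)CC2)C1=O` is hydrogen in place of methoxy on an aromatic carbon. Among the compounds with values here, no measured pair shows what such a change does in this assay, so the direction is open and the step could be none beyond the scatter or larger. Compound 4 is expected to give about 300 mg/kg, within 100 mg/kg to 1000 mg/kg, with a real chance that no number is obtained.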

Compound 4, minimum effective dose: "not active" (no number reported)
Compound 4: no number reported; the estimate stays without a comparison.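

Compound 3 and compound 4 both lack a number, so no step can be read between them. The compounds shown leave open what changing 3-methoxyphenyl to phenyl does in this assay. No data here point to a cause.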